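Series notes: phenethyl in place of 4-methoxybenzyl

The source may report more compounds than this note shows. Statements on the series, on what has been measured and on what is new or still open speak of the compounds shown alone.

compound 1 `O=C(NO)c1ccc(CN2C(=O)NC(Cc3ccc(Cl)cc3)(c3ccccc3)C2=O)cc1`: 54 nM
compound 2 `COc1ccc(CC2(c3ccccc3)NC(=O)N(Cc3ccc(C(=O)NO)cc3)C2=O)cc1`: 72.4 nM

In an assay on isolated protein for inhibition of protein deacetylase HDAC6 (Homo sapiens), read by fluorescence, with stated times of 10 min and 2 h (a higher number here means a weaker inhibitor, a lower number a stronger inhibitor), compound 2 holds the higher of the two numbers shown, with compound 1 nearest, and the step of a 1.3-fold higher number from compound 1 to compound 2 (0.13 log units; within the scatter) lies within the scatter. Compound 3 `O=C(NO)c1ccc(CN2C(=O)NC(CCc3ccccc3)(c3ccccc3)C2=O)cc1` differs from compound 2 by benzyl in place of 4-methoxyphenyl on a saturated chain carbon bound to a saturated ring carbon. Among the measured compounds shown here, the only measured step touches the same aryl group and stayed within the scatter, so no large movement is indicated, though a loss of the methoxy and a lengthened chain together have no direct precedent here. The step of a 1.3-fold higher number from compound 2 to compound 3 (0.12 log units; within the scatter) is expected to be small. Compound 3 is estimated at 95 nM, within 40 nM to 250 nM.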

Compound 3, half-maximal inhibitory concentration: 24.7 nM
For compound 3 the middle estimate is 3.8-fold (0.59 log units) above the measured one; measured number below the stated range.
By their numbers in this assay, from the lowest: compound 3; then compounds 1 and 2 (each within the scatter of the next).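

In this assay, among the compounds shown here, this position shows a change beyond the scatter for the first time: a 2.9-fold lower number from compound 2 to compound 3 (0.47 log units; beyond the scatter) and a 2.2-fold lower number from compound 1 to compound 3 (0.34 log units; beyond the scatter), whereas methoxy in place of chloro on an aromatic carbon stayed within it. Both modest steps replace a substituted benzyl with phenethyl, so chain length and loss of the ring substituent change together and cannot be separated. Nothing available accounts for the lower number.

Open, on these data alone, is whether 4-methoxyphenethyl or 4-chlorophenethyl would keep the lower number of compound 3. Also open, as far as these compounds go, is how phenylpropyl, a longer chain, or unsubstituted benzyl would read here.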